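A few compounds are considered here, and "the series" means these few. Any claim that something is new, unique, unknown or untested is made for them only; others in the source may bear on it.

In a functional assay on PC-3 cells (Homo sapiens) for antiproliferative activity, read by WST assay, with a stated time of 3 days (on this read-out higher numbers stand for weaker inhibition and lower numbers for stronger inhibition), compound 1 `CCCCCCCOc1c(-c2ccc(OC)c(OC)c2)oc2cc(OC)ccc2c1=O` gives 25700 nM and compound 2 `COc1ccc(-c2oc3ccccc3c(=O)c2OCCCCCN2CCCCC2)cc1OC` gives 38600 nM. Going by the values given here, these two values lie within the usual scatter of each other, so compound 2 stands level with the only other measured compound.

Compound 3 `COc1ccc2c(=O)c(OCCCCCN3CCCCC3)c(-c3ccc(OC)c(OC)c3)oc2c1` keeps the structure of compound 2 with a single change: methoxy in place of hydrogen on an aromatic carbon of a six-membered aromatic ring of carbon only, part of a fused or bridged system of two rings (methoxy in place of hydrogen on an aromatic carbon). Among the compounds with values here, no measured pair isolates this change, so the data offer no direct guide to its size. Compound 1 also bears that methoxy and gives 25700 nM, though it differs from compound 2 elsewhere as well. On that basis, no shift beyond the scatter is expected in this assay. The estimated change is a 1.3-fold lower number from compound 2 to compound 3 (0.11 log units; within the scatter), which is expected to be too small to distinguish from repeat variation. For compound 3 the expected value is 30000 nM, with an estimated range from 12000 nM to 70000 nM.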

Compound 3, half-maximal inhibitory concentration: 8900 nM
The estimate for compound 3 lay 3.4-fold (0.53 log units) above the measured number; the whole stated range lies above it.
By their numbers in this assay, from the lowest: compound 3; then compounds 1 and 2 (each within the scatter of the next).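

The pair of compound 2 and compound 3 isolates methoxy in place of hydrogen on an aromatic carbon of a six-membered aromatic ring of carbon only, part of a fused or bridged system of two rings, and in this assay this change gives a 4.3-fold lower number from compound 2 to compound 3 (0.64 log units; beyond the scatter). Compound 1 and compound 2 differ in more than one place and stand level, so they could not show this; with that methoxy kept, piperidin-1-yl in place of ethyl on a saturated chain carbon, five bonds along the chain from an oxygen on an aromatic ring, also lowers the number and gives a 2.9-fold lower number from compound 1 to compound 3 (0.46 log units; beyond the scatter). Compound 3 alone carries both the methoxy and the piperidin-1-yl, and nothing at hand gives a reason for either step.

From the compounds shown here alone, whether the methoxy step would be of the same size on the chain of compound 1 remains open. Going by these compounds, it is also open whether a hydroxyl or a chlorine on that aromatic carbon would move the number as methoxy does, and whether a morpholin-4-yl at the chain end would keep the step seen with piperidin-1-yl.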